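Fluoro for Bromo on the Indole of a Thiazole Amide

This account rests on a few compounds, and the source may have more. Where it says the series, first, only, none or still open, it means among the compounds named here.

Compound 1 `COc1ccc2[nH]cc(-c3nc(C(=O)Nc4cc(OC)c(OC)c(OC)c4)cs3)c2c1` in an ADME assay on HEK-293T cells (Homo sapiens) for cytotoxicity, read by MTT assay, with a stated time of 48 h, in the absence of a further agent (a higher number here means a weaker inhibitor, a lower number a stronger inhibitor), gives 8600 nM. Compound 2 `COc1cc(NC(=O)c2csc(-c3c[nH]c4ccc(Br)cc34)n2)cc(OC)c1OC` sits at the limit of > 100000 nM in this assay, at which 1 of the 2 values shown sits: in this assay compound 2 gives > 100000 nM, a limit rather than a number. Among the compounds with values here, the one measured comparison is an at least 11-fold higher number from compound 1 to compound 2 (1.06 log units; beyond the scatter). Compound 3 `COc1cc(NC(=O)c2csc(-c3c[nH]c4ccc(F)cc34)n2)cc(OC)c1OC` differs from compound 2 by fluoro in place of bromo on an aromatic carbon. Within the data shown here, no measured step matches this exchange, and the floor set by compound 2 leaves the direction open; anything from the level of compound 1 up to that of compound 2 would fit. Compound 3 is expected to give about 50000 nM in this assay, between 10000 nM and 150000 nM. That estimate means an at least 2.0-fold lower number from compound 2 to compound 3 (0.30 log units; that floor lies within the scatter).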

Compound 3, half-maximal inhibitory concentration: > 100000 nM
Compound 3 was reported as a limit (the forecaster's own chance of this, stated with the estimate: 40%); middle value at least 2.0-fold (0.30 log units) away from the limit.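

Replacing methoxy at this position raises the number with fluoro as well as with bromo, so the earlier rise is not tied to bromo alone: fluoro gives an at least 11-fold higher number from compound 1 to compound 3 (1.06 log units; beyond the scatter). The step between compound 2 and compound 3 cannot be read, since each value is a limit and not a number: the limit of > 100000 nM in this assay, at which 2 of the 3 values shown sit.

Going by these compounds, whether bromo and fluoro differ at all in this assay stays open. Also open, on these data alone, is how an amine, a nitrile or an ethoxy group at this position would compare with methoxy.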